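The source may report more compounds than this note shows. Statements on the series, on what has been measured and on what is new or still open speak of the compounds shown alone.

Compound 3 `COc1cc2c(Oc3ccc(NC(=O)c4nn(-c5ccc([N+](=O)[O-])cc5)c(=O)c5ccccc45)cc3F)ccnc2cc1OCCCN1CCCCC1` gives 2170 nM in a functional assay on HT-29 cells (Homo sapiens) for cytotoxicity, read by MTT assay, with a stated time of 72 h (a lower number here means a stronger inhibitor, a higher number a weaker inhibitor), the second highest of three numbers. Its nearest neighbour is compound 1 `COc1ccc(-n2nc(C(=O)Nc3ccc(Oc4ccnc5cc(OCCCN6CCCC6)c(OC)cc45)c(F)c3)c3ccccc3c2=O)cc1` at 2360 nM, within the scatter; compound 2 `COc1cc2c(Oc3ccc(NC(=O)c4nn(-c5ccccc5F)c(=O)c5ccccc45)cc3F)ccnc2cc1OCCCN1CCCCC1` at 630 nM is the only one beyond it, and that separation is the step of a 3.4-fold higher number from compound 2 to compound 3 (0.54 log units; beyond the scatter). Compound 4 `COc1ccc(-n2nc(C(=O)Nc3ccc(Oc4ccnc5cc(OCCCN6CCCCC6)c(OC)cc45)c(F)c3)c3ccccc3c2=O)cc1` arises from compound 3 by methoxy in place of nitro on an aromatic carbon. Within the data shown here, no measured step covers this exact exchange; the nearest guide is compound 1, which carries the same methoxyphenyl on a shorter cyclic amine and gives 2360 nM, close to compound 3. The change is therefore expected to leave the number within the scatter, with a 1.2-fold lower number from compound 3 to compound 4 (0.08 log units; within the scatter), and compound 4 is estimated at 1800 nM, between 600 nM and 5400 nM.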

Compound 4, half-maximal inhibitory concentration: 1450 nM
Beside the measured number, compound 4's estimate is 1.2-fold (0.09 log units) above it; low and high end bracket the measured number.
By their numbers in this assay, from the lowest: compound 2; then compounds 4, 3 and 1 (each within the scatter of the next).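

In this assay, methoxy in place of nitro on this aromatic carbon leaves the number within the scatter (a 1.5-fold lower number from compound 3 to compound 4 (0.18 log units; within the scatter)), and so does piperidin-1-yl in place of pyrrolidin-1-yl (a 1.6-fold lower number from compound 1 to compound 4 (0.21 log units; within the scatter)). The 2-fluorophenyl group still stands apart, now from the 4-methoxyphenyl group as well (a 2.3-fold higher number from compound 2 to compound 4 (0.36 log units; beyond the scatter)), so the separation seen with the 4-nitrophenyl group holds for a second substituent. Nothing available accounts for these numbers. Going by these compounds, it remains open whether an amine or a carboxylic acid on this aromatic carbon would shift the number beyond the scatter.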